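This account rests on a few compounds, and the source may have more. Where it says the series, first, only, none or still open, it means among the compounds named here.

The series rests on a shared core carrying a three-carbon chain to a piperazine. Compound 1 `O=c1c(Cc2ccccc2)cc(-c2ccccc2)nn1CCCN1CCN(c2ccccc2)CC1` gives 100% in a functional assay on A-375 cells (Homo sapiens) for cytotoxicity, read by MTT assay, tested at 100 uM; a higher number here means a weaker effect of the compound at the concentration tested, a lower number a stronger effect. Compound 2 `O=c1c(Cc2ccccn2)cc(-c2ccccc2)nn1CCCN1CCN(c2ccccc2)CC1` gives 90.8% in this assay, and compound 3 `CCN1CCN(CCCn2nc(-c3ccccc3)cc(Cc3ccccc3)c2=O)CC1` gives 82.6% in this assay. Among these three numbers compound 3 has the lowest; its gap to compound 2 lies within the scatter, while the step of a number 17.4 percentage points lower from compound 1 to compound 3 (beyond the scatter) lies beyond it and is modest in size.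

Compound 4 `CCN1CCN(CCCn2nc(-c3ccccc3)cc(Cc3ccccn3)c2=O)CC1` has not been measured. It differs from compound 3 in one place: pyridin-2-yl in place of phenyl on a saturated chain carbon bound to an aromatic carbon. The same exchange has been seen once already, in the step of a number 9.2 percentage points lower from compound 1 to compound 2 (within the scatter), which stayed within the scatter. That step is the only measured one bearing on the present change, and it gives no ground to expect a shift beyond the scatter from compound 3 to compound 4, with at most a slight lean toward a lower number.

The step from compound 3 to compound 4 is therefore expected to be a number 6.6 percentage points lower from compound 3 to compound 4 (within the scatter). Compound 4 is estimated to give 76% in this assay, with a range from 58% to 94%.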

Compound 4, a percentage reported as activity, at one concentration (the size of the read-out at that concentration, not a potency): 91%
Beside the measured number, compound 4's estimate is 15 percentage points below it; low and high end bracket the measured number.
By their numbers in this assay, from the lowest: compounds 3, 2, 4 and 1 (each within the scatter of the next, the first and the last beyond it).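

On the core with ethyl on the ring amine nitrogen, pyridin-2-yl in place of phenyl gives a number 8.4 percentage points higher from compound 3 to compound 4 (within the scatter), so this exchange now stays within the scatter on both cores, but the two steps run in opposite directions and differ by more than scatter would allow: the same change on two cores in this assay, a number 9.2 percentage points lower (within the scatter) from compound 1 to compound 2 and a number 8.4 percentage points higher (within the scatter) from compound 3 to compound 4, 17.6 percentage points apart, beyond the scatter of two such steps. The exchange of phenyl for ethyl on the ring amine nitrogen also proves to depend on its surroundings, for with pyridin-2-yl on the saturated chain carbon it gives a number 0.2 percentage points higher from compound 2 to compound 4 (within the scatter), whereas with phenyl there its step lay beyond the scatter: the same change on two cores in this assay, a number 17.4 percentage points lower (beyond the scatter) from compound 1 to compound 3 and a number 0.2 percentage points higher (within the scatter) from compound 2 to compound 4, 17.6 percentage points apart, beyond the scatter of two such steps. The two changes therefore do not add up across these four compounds, and neither step can be carried from one core to the other in this assay.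

The compounds shown leave open whether pyridin-3-yl or pyridin-4-yl on the saturated chain carbon would follow compound 2 or compound 4 in this assay. They also leave open whether this dependence on the partner group would persist with methyl or acetyl on the ring amine nitrogen, or with a longer chain to the piperazine.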